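This account rests on a few compounds, and the source may have more. Where it says the series, first, only, none or still open, it means among the compounds named here.

Working notes on the series.

Compound 1 `COc1ccc(C(=O)c2ccc3c(c2)C=CC(C)(C)O3)c(NC(=O)CO)c1` and compound 3 `COc1ccc(C(=O)c2cc(OC)c(OC)c(OC)c2)c(NC(=O)CO)c1` carry the same amide side chain on two different cores; the difference between the two cores is not broken down here. In a functional assay on MCF7 cells (Homo sapiens) for antiproliferative activity, read by MTT assay, with a stated time of 48 h (a higher number here means a weaker inhibitor, a lower number a stronger inhibitor), compound 1 gives 200 nM, and compound 3 gives 230 nM; the two values lie within the usual scatter of each other, so nothing separates them.

Compound 2 `CNCC(=O)Nc1cc(OC)ccc1C(=O)c1ccc2c(c1)C=CC(C)(C)O2` is compound 1 with one change, (methylamino in place of hydroxy on a saturated chain carbon bound to a carbonyl carbon). In this assay compound 2 gives 1210 nM, which is a 6.1-fold higher number from compound 1 to compound 2 (0.78 log units; beyond the scatter). For the measured compounds named here, this is the only measured instance of the change, so it is a single data point rather than a pattern.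

Compound 4 `CNCC(=O)Nc1cc(OC)ccc1C(=O)c1cc(OC)c(OC)c(OC)c1` is not yet measured. It differs from compound 3 by methylamino in place of hydroxy on a saturated chain carbon bound to a carbonyl carbon. The place of the change reads the same, word for word, as for the step from compound 1 to compound 2, so it is the same change made on the core of compound 3 instead of the core of compound 1.

For compound 4 the expected step in this assay is a 6.1-fold higher number from compound 3 to compound 4 (0.78 log units; beyond the scatter), because the same change gave a 6.1-fold higher number from compound 1 to compound 2 (0.78 log units; beyond the scatter). The expectation rests on that one step and on compound 3 giving 230 nM, the starting point of the new step. Compound 4 is therefore estimated at 1400 nM, with a likely range from 600 nM to 3300 nM, the width allowing for the change being transferred to a different core.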

Compound 4, half-maximal inhibitory concentration: 550 nM
Estimate against measurement, compound 4: 2.5-fold (0.41 log units) above, outside the stated range (below it).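

In this assay, methylamino in place of hydroxy on a saturated chain carbon bound to a carbonyl carbon gives a 2.4-fold higher number from compound 3 to compound 4 (0.38 log units; beyond the scatter), which is the same direction as on the other core. Set side by side, the two steps cannot be told apart in size: the same change on two cores in this assay, a 6.1-fold higher number (0.78 log units; beyond the scatter) from compound 1 to compound 2 and a 2.4-fold higher number (0.38 log units; beyond the scatter) from compound 3 to compound 4, 2.5-fold (0.40 log units) apart, within the scatter of two such steps. This shows that on these two cores the change carries over in direction and that its size on one core is compatible with its size on the other, but it does not show that the two sizes are equal, and two steps on two cores are too few to make a rule for the series or to say why the number rises.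

The compounds shown leave open whether other groups at this place, such as a primary amine, a dimethylamino group, a carboxylic acid or a longer chain, would give steps that also agree across the two cores. They also leave open whether the change would keep its direction on a third core.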